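The compounds below may be only part of what the source reports. "The series", "measured", "known", "first", "only" and "open" are said of these compounds alone.

Measured in a functional assay on P388 cells (Mus musculus) for antiproliferative activity; on this read-out higher numbers stand for weaker inhibition and lower numbers for stronger inhibition:
- compound 1 `Nc1ccc(S(=O)(=O)Nc2cccc3cc[nH]c23)cc1`: 14 ug/mL
- compound 2 `COc1ccc(S(=O)(=O)Nc2cccc3c(Cl)c[nH]c23)cc1`: 0.76 ug/mL
- compound 3 `Nc1ccc(S(=O)(=O)Nc2cccc3c(Cl)c[nH]c23)cc1`: 0.81 ug/mL

Compound 3, at 0.81 ug/mL, is level within the scatter with compound 2, at 0.76 ug/mL. Compound 1, at 14 ug/mL, has a far higher number, which here means much weaker inhibition.

The next step leads to compound 4 `CNS(=O)(=O)c1ccc(S(=O)(=O)Nc2cccc3c(Cl)c[nH]c23)cc1`, with methylsulfamoyl in place of amino on an aromatic carbon. The group sits on a six-membered aromatic ring of carbon only, para to a large group.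

Going by the values given here, two measured steps bear on this. The closer one changes the group at this same place, and it gave a 1.1-fold higher number from compound 2 to compound 3 (0.03 log units; within the scatter). The other, a 17-fold lower number from compound 1 to compound 3 (1.24 log units; beyond the scatter), is large, but it concerns the chloro group, which compound 4 keeps. So the one swap seen at this place made no difference beyond the scatter, and a step beyond the scatter is not expected here. From the compounds shown here alone, that rests on a single swap, and methylsulfamoyl itself is untested in this small set, so the range must stay wide.

The expected change is a 1.6-fold lower number from compound 3 to compound 4 (0.21 log units; within the scatter), which would lie within the scatter.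

For compound 4 the estimated value is 0.5 ug/mL, with an expected range of 0.12 ug/mL to 2 ug/mL.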

Compound 4, half-maximal inhibitory concentration: 0.9 ug/mL
Estimate against measurement, compound 4: 1.8-fold (0.26 log units) below, within the range that was stated.
By their numbers in this assay, from the lowest: compounds 2, 3 and 4 (each within the scatter of the next); then compound 1.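

In this assay, methylsulfamoyl, with 5 heavy atoms, replaces amino, with 1 heavy atom, and gives a 1.1-fold higher number from compound 3 to compound 4 (0.05 log units; within the scatter); replacing methoxy with it gives a 1.2-fold higher number from compound 2 to compound 4 (0.07 log units; within the scatter). Before this, the position had been probed only by the exchange of methoxy and amino, but compounds 2, 3 and 4 now show that a much larger group on this aromatic carbon, para to a large group, also leaves the number within the scatter. The data offer no measurement that would explain this flat response.

The three groups seen here do not show how far the flat response extends, and a carboxylic acid, a tertiary amine or a longer alkyl chain at the same place could still shift the number. From the compounds shown here alone, it also remains open whether methylsulfamoyl or methoxy would depend on the chloro group as amino does, since removing chloro is seen only for the amino compounds, where adding it gives a 17-fold lower number from compound 1 to compound 3 (1.24 log units; beyond the scatter).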